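The source may hold more compounds than are shown below. What is called first, only, known or untested is meant among the compounds shown, and "the series" means these compounds.

Measured in a functional assay on DU-145 cells (Homo sapiens) for cytotoxicity, read by MTT assay, with a stated time of 72 h; a lower number here means a stronger inhibitor, a higher number a weaker inhibitor:
- compound 1 `Cc1cc(/C=C/c2ccc(O)cc2)[nH]n1`: 45800 nM
- compound 2 `COc1ccc(/C=C/c2cc(C)n[nH]2)cc1`: 8400 nM
- compound 3 `COc1cc(/C=C/c2cc(C)[nH]n2)ccc1O`: 32200 nM

Compound 2 has the lowest number of the three in this assay, and its values against compound 1 and compound 3 both differ by more than the usual scatter. Compound 4 `COc1ccc(/C=C/c2cc(C)n[nH]2)cc1OC` differs from compound 2 by methoxy in place of hydrogen on an aromatic carbon.

Going by the values given here, the only measured step is a 5.5-fold lower number from compound 1 to compound 2 (0.74 log units; beyond the scatter), a modest change beyond the scatter. That step is a different change, methyl in place of hydrogen on an oxygen, so it bears on the new methoxy only indirectly. Among the compounds with values here, compound 3 also carries a ring methoxy, but no step is measured for it. All that can be said is that compound 1 at 45800 nM and compound 3 at 32200 nM lie within the scatter of each other. The data therefore give no direction for the change, and no shift beyond the scatter is expected in this assay. The expected step is a 1.1-fold higher number from compound 2 to compound 4 (0.03 log units; within the scatter), with wide uncertainty. The estimated value for compound 4 is 9000 nM, within an expected range from 3500 nM to 24000 nM.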

Compound 4, half-maximal inhibitory concentration: 18500 nM
Compound 4: middle estimate off by 2.1-fold (0.31 log units), on the low side; the measured number falls inside the stated range.
By their numbers in this assay, from the lowest: compound 2; then compounds 4, 3 and 1 (each within the scatter of the next, the first and the last beyond it).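

In this assay, going by these compounds alone, methoxy in place of hydrogen on the aromatic carbon ortho to a methoxy group and meta to a group of 8 heavy atoms gives a 2.2-fold higher number from compound 2 to compound 4 (0.34 log units; beyond the scatter), the first directly measured step for adding a ring methoxy. The direction is towards a weaker inhibitor, so at this position the added group does not extend the gain seen in a 5.5-fold lower number from compound 1 to compound 2 (0.74 log units; beyond the scatter), although that step is a different change, on an oxygen, and the two share no position. No supporting measurement bears on why the added methoxy shifts the number in this direction.

Going by these compounds, the step is a single modest one at one position, on a background of compound 2, so it remains open whether the same direction holds for other groups here, such as fluorine, an amine, a carboxylic acid or a longer chain like butoxy. Also open, on these data alone, is whether methoxy at this position would give a step of the same size and direction on a core carrying a free hydroxyl, as compound 1 does.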